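Swapping hydroxy for trifluoromethyl on the aromatic ring

The compounds below may be only part of what the source reports. "The series", "measured", "known", "first", "only" and "open" are said of these compounds alone.

Compound 1 `CC1CC/C(=N\Nc2ccc(F)cc2)c2ncc(C(=O)O)c(=O)n21`: 1200 nM
Compound 2 `CC1CC/C(=N\Nc2ccc(O)cc2)c2ncc(C(=O)O)c(=O)n21`: 1300 nM
Compound 3 `Cc1cccc(N/N=C2\CCC(C)n3c2ncc(C(=O)O)c3=O)c1`: 72900 nM

In a functional assay (mast cells) for inhibition, with Rattus norvegicus as the target (a higher number here means that more compound is needed for the effect, a lower number that less compound is needed), compound 2 gives 1300 nM. This matches compound 1 within the scatter, and both numbers lie far under that of compound 3.

Compound 4 `CC1CC/C(=N\Nc2ccc(C(F)(F)F)cc2)c2ncc(C(=O)O)c(=O)n21` has not yet been measured. Its difference from compound 2 is trifluoromethyl in place of hydroxy on an aromatic carbon, para to a large group.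

The closest guide is the exchange of fluoro for hydroxy on that same carbon, which gave a 1.1-fold higher number from compound 1 to compound 2 (0.03 log units; within the scatter). The large steps are a 61-fold higher number from compound 1 to compound 3 (1.78 log units; beyond the scatter) and a 56-fold higher number from compound 2 to compound 3 (1.75 log units; beyond the scatter), but compound 3 lacks a group on that carbon, and compound 4 keeps one. Within the data shown here, no measured compound carries a group as large as trifluoromethyl there, so a modest rise in the number is expected in this assay, with a larger one not excluded. The expected change is a 1.9-fold higher number from compound 2 to compound 4 (0.28 log units; within the scatter). Compound 4 is estimated at 2500 nM, with an expected range of 700 nM to 15000 nM.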

Compound 4, half-maximal effective concentration: 280 nM
For compound 4 the middle estimate is 8.9-fold (0.95 log units) above the measured one, and the stated range ends above it.
By their numbers in this assay, from the lowest: compound 4; then compounds 1 and 2 (each within the scatter of the next); then compound 3.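

Fluoro and hydroxy on the aromatic carbon para to a large group had given numbers within the scatter of each other, so this position could have seemed insensitive to its substituent. Trifluoromethyl shows otherwise in this assay, with a 4.6-fold lower number from compound 2 to compound 4 (0.67 log units; beyond the scatter) and a 4.3-fold lower number from compound 1 to compound 4 (0.63 log units; beyond the scatter), so the group on this carbon can change the amount of compound needed. No measurement available here explains this shift.

Going by these compounds, it remains open whether a chloro, methyl or nitrile on this same carbon would give a number like that of compound 4 or like those of compound 1 and compound 2. The 3-methylphenyl group of compound 3 does not answer this, and how trifluoromethyl would behave as a 3-trifluoromethylphenyl group is also unknown.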